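Carbamate leaving group swap on a fatty-acid amide hydrolase inhibitor

The source may hold more compounds than are shown below. What is called first, only, known or untested is meant among the compounds shown, and "the series" means these compounds.

Measured compounds:
Compound 1, `CCCCCCCCOc1ccc(NC(=O)Oc2ccccc2F)cc1`: 19 nM
Compound 2, `CCCCOc1ccc(C(CC)NC(=O)Oc2ccccc2F)cc1`: 7.7 nM

In an assay on H4 cells for inhibition of Fatty-acid amide hydrolase 1 (Homo sapiens) (a lower number here means a stronger inhibitor, a higher number a weaker inhibitor), compound 1 gives 19 nM. Compound 2 has the lowest number of the two in this assay, where compound 2 gives 7.7 nM, and its nearest neighbour, compound 1, lies beyond the scatter above it.

Compound 3, `CCCCOc1ccc(C(CC)NC(=O)Oc2cccc(N(C)C)c2)cc1`, has not been measured. It differs from compound 2 by 3-(dimethylamino)phenyl in place of 2-fluorophenyl on an oxygen next to a carbonyl group. Among the compounds with values here, no measured pair shows this change, so its effect is not known from these data. Both measured compounds carry the 2-fluorophenyl group, and nothing here shows what another group on that oxygen does. A modest weakening in this assay is expected for compound 3, with a step of a 3.9-fold higher number from compound 2 to compound 3 (0.59 log units; beyond the scatter) from compound 2. Compound 3 is therefore estimated at 30 nM, within a range from 6 nM to 150 nM.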

Compound 3, half-maximal inhibitory concentration: 54 nM
Compound 3: middle estimate off by 1.8-fold (0.26 log units), on the low side, and the stated range covers the measured number.
By their numbers in this assay, from the lowest: compound 2; then compound 1; then compound 3.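

Putting 3-(dimethylamino)phenyl in place of 2-fluorophenyl on the oxygen next to a carbonyl group weakens inhibition in this assay, with a 7.0-fold higher number from compound 2 to compound 3 (0.85 log units; beyond the scatter). Within the data shown here, this is the first measured sign that the group at this position affects the read-out, since the earlier compounds both carried 2-fluorophenyl there, and compound 3 still inhibits at 54 nM, so this change reduces activity without abolishing it. No measurement at hand accounts for the size of this step.

Among these compounds, because the fluorine leaves and the dimethylamino group enters in one change, the single step cannot show what each contributes alone, and an unsubstituted phenyl group or a 3-methoxyphenyl group on this oxygen would help to separate them. On these data alone, it also remains open whether the same swap would produce a similar step on the core of compound 1.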